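Thiophene isomer swap on a nucleoside-like scaffold in BJ cells

A few compounds are considered here, and "the series" means these few. Any claim that something is new, unique, unknown or untested is made for them only; others in the source may bear on it.

Three compounds of this series carry numbers in an ADME assay on BJ cells (Homo sapiens), read by MTT assay, with a stated time of 72 h; on this read-out higher numbers stand for weaker inhibition and lower numbers for stronger inhibition. Compound 1 `COc1ncnc2c1c(-c1cccs1)cn2[C@@H]1O[C@H](CO)[C@@H](O)[C@H]1O` gives 62800 nM in this assay. Compound 3 `O=c1[nH]cnc2c1c(-c1cc3ccccc3o1)cn2[C@@H]1O[C@H](CO)[C@@H](O)[C@H]1O` gives 62700 nM in this assay. Compound 2 `CNc1ncnc2c1c(-c1ccsc1)cn2[C@@H]1O[C@H](CO)[C@@H](O)[C@H]1O` gives only a limit of the assay in this assay, > 100000 nM, so no number is known for it. Within the shown set compound 2 thus sits at the limit of > 100000 nM in this assay, at which 1 of the 3 values shown sits, the weakest end of what was measured, while compound 1 and compound 3 sit close together and cannot be told apart within the usual scatter.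

The next compound, compound 4 `CNc1ncnc2c1c(-c1cccs1)cn2[C@@H]1O[C@H](CO)[C@@H](O)[C@H]1O`, is the isomer of compound 2: thiophen-2-yl in place of thiophen-3-yl on an aromatic carbon. No pair of measured compounds differs in this one place alone, so the size of the step cannot be read off from the numbers shown. Both compound 1, which carries the entering thiophen-2-yl, and compound 2 lie at or near the weak end of this assay, so no step beyond the scatter is expected, and a result at the limit again is quite likely.

For compound 4 the expected value in this assay is therefore 90000 nM, with a range from 40000 nM to 200000 nM; the step this expectation implies is an at least 1.1-fold lower number from compound 2 to compound 4 (0.04 log units; that floor lies within the scatter).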

Compound 4, half-maximal inhibitory concentration: > 100000 nM
Compound 4 gave a limit, no number; the forecaster's own chance of this, stated with the estimate: 55%; at least 1.1-fold (0.04 log units) between middle value and limit.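

In this assay, compound 4 sits at the assay limit, as compound 2 does, so the swap of thiophen-3-yl for thiophen-2-yl on this aromatic carbon cannot be sized; with a limit at both ends, that step cannot be read. Among these compounds, the only readable step lies in the other place: with thiophen-2-yl held constant, methylamino in place of methoxy on an aromatic carbon gives an at least 1.5-fold higher number from compound 1 to compound 4 (0.20 log units; that floor lies within the scatter), and as that floor lies within the scatter, the step does not establish a real change. With methylamino held constant, both thiophene isomers now lie at the weak end of the read-out: the limit of > 100000 nM in this assay, at which 2 of the 4 values shown sit.

Going by these compounds, it remains open whether the point of attachment of the thiophene has any effect in this assay, and how far the true values of compound 2 and compound 4 lie beyond the limit. A phenyl or furan-2-yl group on this aromatic carbon, or an amino or dimethylamino group in place of methylamino, would be further changes to set against these compounds, but the compounds shown say nothing about how such groups would read.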